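Methyl in Place of Chloro: What the Numbers Allow

This account rests on a few compounds, and the source may have more. Where it says the series, first, only, none or still open, it means among the compounds named here.

Compound 1 `O=C(O)CCC(=O)/C=C/c1cn(-c2ccccc2)nc1-c1ccccc1` and compound 2 `O=C(O)CCC(=O)/C=C/c1cn(-c2ccccc2)nc1-c1ccc(Cl)cc1` share one core, compound 2 carrying chloro in place of hydrogen on an aromatic carbon. In a functional assay on the whole organism (strain albino) for inhibition, with Rattus norvegicus as the target, read by paw edema, with stated times of 30 min and 3 h, at a dose of 50 mg/kg by the oral route (a higher number here means more inhibition at the dose given (going by the name of the read-out), a lower number less inhibition), compound 1 gives 15.5% and compound 2 gives 6.32%; the step of a number 9.2 percentage points lower from compound 1 to compound 2 (within the scatter) lies within the scatter, so the two cannot be ranked. Compound 2 stands at the lowest of the two numbers, with compound 1 nearest, the gap within the scatter. Compound 3 `Cc1ccc(-c2nn(-c3ccccc3)cc2/C=C/C(=O)CCC(=O)O)cc1` is reached from compound 2 by methyl in place of chloro on an aromatic carbon. Among the measured compounds shown here, the only measured step touching this position, a number 9.2 percentage points lower from compound 1 to compound 2 (within the scatter), stayed within the scatter, and no measured exchange of chloro for methyl exists, so no step beyond the scatter is expected in this assay in either direction. Compound 3 is therefore estimated at 10%, with a range from 0% to 25%. The expected step is a number 3.7 percentage points higher from compound 2 to compound 3 (within the scatter).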

Compound 3, a percentage reported as inhibition, in the whole organism at one dose (the size of the read-out at that dose, not a potency): 11.5%
For compound 3 the middle estimate is 1.5 percentage points below the measured one; the range from low to high includes it.
By their numbers in this assay, from the lowest: compounds 2, 3 and 1 (each within the scatter of the next).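

In this assay the step of methyl in place of chloro reads as a number 5.2 percentage points higher from compound 2 to compound 3 (within the scatter) and the step of methyl in place of hydrogen reads as a number 4 percentage points lower from compound 1 to compound 3 (within the scatter). With these two steps, hydrogen, chloro and methyl on this aromatic carbon, para to a large group, all lie within the scatter of one another, so the three cannot be ranked. At this one dose, neither a chlorine nor a carbon as the entering atom has yet produced a step beyond the scatter at this position, and nothing measured here bears on why the three numbers lie so close.

From the compounds shown here alone, whether a methoxy group, a hydroxyl or an amine at this position would move the number beyond the scatter stays open. So does whether replacing the carboxylic acid with an amide would do so, or whether the three compounds would remain inseparable at another dose.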